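The source may hold more compounds than are shown below. What is called first, only, known or untested is meant among the compounds shown, and "the series" means these compounds.

Measured so far:
Compound 1 `COc1cccc(NC(=O)CSc2nc(Nc3ccccc3)c3ccccc3n2)c1`: 21700 nM
Compound 2 `O=C(CSc1nc(Nc2ccccc2)c2ccccc2n1)Nc1ccc(F)cc1`: 34100 nM
Compound 3 `C=CC(=O)Nc1cccc(NC(=O)CSc2nc(Nc3cccc(OC)c3)c3ccccc3n2)c1`: 12900 nM

All three were tested in a functional assay on MDA-MB-231 cells (Homo sapiens) for inhibition, read by MTT assay, with a stated time of 72 h; on this read-out lower numbers stand for stronger inhibition and higher numbers for weaker inhibition. Compound 1 and compound 2 share one core and differ in a single place, (4-fluorophenyl in place of 3-methoxyphenyl on an amide-type nitrogen); that change made a step of a 1.6-fold higher number from compound 1 to compound 2 (0.20 log units; within the scatter), so the two numbers cannot be told apart. Compound 3 has a different core, and the difference between the two cores is not broken down here. Its value lies within the scatter of compound 1, while compound 2 stands a step beyond it.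

Compound 4 `C=CC(=O)Nc1cccc(NC(=O)CSc2nc(Nc3ccc(F)cc3)c3ccccc3n2)c1` has not yet been measured. It is made from compound 3 by the change (4-fluorophenyl in place of 3-methoxyphenyl on a nitrogen on an aromatic ring). This is the same kind of change as that from compound 1 to compound 2, but not the same: in compound 1 the group sits on an amide-type nitrogen whose other neighbour is a carbonyl carbon, whereas in compound 3 it sits on a nitrogen on an aromatic ring whose other neighbour is an aromatic carbon. Going by the values given here, with only one earlier example of this swap, the simplest expectation is that the step from compound 3 to compound 4 will be about the same size, a 1.6-fold higher number from compound 3 to compound 4 (0.19 log units; within the scatter), resting on compound 1 to compound 2 having given a 1.6-fold higher number from compound 1 to compound 2 (0.20 log units; within the scatter). Compound 4 is therefore expected to give about 20000 nM in this assay, with a likely range from 9000 nM to 45000 nM.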

Compound 4, half-maximal inhibitory concentration: 9490 nM
Compound 4: the middle estimate sits 2.1-fold (0.32 log units) above what was measured; the measured number falls inside the stated range.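

In this assay, putting 4-fluorophenyl in place of 3-methoxyphenyl on a nitrogen on an aromatic ring gave a 1.4-fold lower number from compound 3 to compound 4 (0.13 log units; within the scatter), a step too small to be told apart from no change at all. Set beside the earlier swap, this step differs from it by no more than repeated measurement alone could produce: the same change on two cores in this assay, a 1.6-fold higher number (0.20 log units; within the scatter) from compound 1 to compound 2 and a 1.4-fold lower number (0.13 log units; within the scatter) from compound 3 to compound 4, 2.1-fold (0.33 log units) apart, within the scatter of two such steps. This shows that neither core gave a step clear of the scatter, so the two pairs agree as far as can be told, but it does not show that a real effect of this change would carry from one core to the other, since neither pair shows such an effect and the swap sits on an amide-type nitrogen in one pair and on a nitrogen on an aromatic ring in the other.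

The compounds shown leave open whether a different group in either place, such as an amine or a carboxylic acid, would give a step beyond the scatter. Also open is what the difference between the core of compound 1 and the core of compound 3 contributes on its own, as no pair shown isolates it.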